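Series notes: cyclic sulfonamide homologation on the fused core

This account rests on a few compounds, and the source may have more. Where it says the series, first, only, none or still open, it means among the compounds named here.

Measured so far:
compound 1, `Cc1cccc(C(=O)Nc2ccc3c(c2)CC(NS(C)(=O)=O)C3)c1-c1ccc(Cl)cc1` — 6.6 nM
compound 2, `O=C(NC1Cc2ccc(NC(=O)c3ccccc3-c3ccc(C(F)(F)F)cc3)cc2C1)c1ccccc1` — 270 nM
compound 3, `COC(=O)NCC1Cc2ccc(NC(=O)c3cc(C)cc(C)c3-c3ccc(C(F)(F)F)cc3)cc2C1` — 2.2 nM

In an assay for inhibition of apolipoprotein B-100 (Homo sapiens), tested at 100 nM (a higher number here means a weaker inhibitor, a lower number a stronger inhibitor), compound 1 stands second highest of the three numbers. Its nearest neighbour is compound 3, which gives 2.2 nM, a lower number, beyond the scatter. Compound 2 gives 270 nM, far higher than compound 1 and the weakest of the set. No single-point step connects any two of these compounds, so the gaps between them cannot be assigned to one change.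

Compound 4, `Cc1cccc(C(=O)Nc2ccc3c(c2)CC(CNS(C)(=O)=O)C3)c1-c1ccc(Cl)cc1`, is the next point and differs from compound 1 in one place: (methanesulfonamido)methyl in place of methanesulfonamido on a saturated ring carbon. The rest of the molecule is kept. Within the data shown here, the only other compound with a chain-linked substituent on that saturated ring carbon is compound 3, but it differs in several further places, so its value of 2.2 nM offers no clean guide for this assay.

With no measured step of this kind in the series, the expected change is modest, either direction, and most likely within the scatter. The estimated step from compound 1 to compound 4 is a 1.3-fold lower number from compound 1 to compound 4 (0.12 log units; within the scatter). Compound 4 is estimated at 5 nM, within a range from 1.5 nM to 20 nM.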

Compound 4, half-maximal inhibitory concentration: 16 nM
The estimate for compound 4 lay 3.2-fold (0.51 log units) below the measured number; measured number inside the range.
By their numbers in this assay, from the lowest: compound 3; then compound 1; then compound 4; then compound 2.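

Among these compounds, on a saturated ring carbon of the five-membered non-aromatic ring, replacing methanesulfonamido with (methanesulfonamido)methyl gives the first step that can be read at a single place: in this assay, a 2.4-fold higher number from compound 1 to compound 4 (0.38 log units; beyond the scatter). The step is modest, but it shows that this position responds to the change even though the two groups have the same counts of hydrogen-bond donors, hydrogen-bond acceptors and double bonds outside aromatic rings, and neither has a ring or a net charge; the difference in these counts lies in the added carbon. No measurement among those shown bears on the reason for the step.

A single step gives a direction for this one change only, and it cannot show whether a longer chain, such as (methanesulfonamido)ethyl, would extend the same trend or reverse it. Also open, as far as these compounds go, is whether the step would hold on other parts of the molecule, and how a free amine or a carboxylic acid would read on the same saturated ring carbon of the shared core.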